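A few compounds are considered here, and "the series" means these few. Any claim that something is new, unique, unknown or untested is made for them only; others in the source may bear on it.

Series core: compound 1 `COc1ccc(OC)c(C2OC(c3cc(OC)c(OC)c(OC)c3)=NN2C(C)=O)c1` and compound 2 `COc1cc(C2=NN(C(C)=O)C(c3ccccc3C(F)(F)F)O2)cc(OC)c1OC`. In a functional assay on PC-3 cells (Homo sapiens) for antiproliferative activity, read by MTT assay, tested at 1 uM (on this read-out lower numbers stand for a weaker effect and higher numbers for a stronger effect at the one concentration tested), compound 1 gives 37.2%, while compound 2 gives -11%; the step of a number 48.2 percentage points lower from compound 1 to compound 2 (beyond the scatter) places compound 2 at the lower of the two numbers, beyond the scatter of compound 1. Compound 3 `COc1cc(C2=NN(C(C)=O)C(c3ccccc3F)O2)cc(OC)c1OC` differs from compound 2 by fluoro in place of trifluoromethyl on an aromatic carbon. Among the compounds with values here, no measured step covers trifluoromethyl against fluoro; the only step known concerns a different group on the same saturated ring carbon and cannot be read across. A step of a number 17 percentage points higher from compound 2 to compound 3 (beyond the scatter) is therefore expected, small and uncertain in direction. Compound 3 is estimated at 6%, within -20% to 38%.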

Compound 3, a percentage reported as inhibition, at one concentration (the size of the read-out at that concentration, not a potency): 13.5%
For compound 3 the middle estimate is 7.5 percentage points below the measured one, and the stated range covers the measured number.
By their numbers in this assay, from the lowest: compound 2; then compound 3; then compound 1.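

In this assay, fluoro in place of trifluoromethyl on the aromatic carbon gives a number 24.5 percentage points higher from compound 2 to compound 3 (beyond the scatter), so this position responds to the group carried there even when the rest of the molecule stays the same. The 2-fluorophenyl group does not reach the level of 2,5-dimethoxyphenyl, with a number 23.7 percentage points lower from compound 1 to compound 3 (beyond the scatter), which places it between the two earlier aryl groups. No data at hand explain either step.

As far as these compounds go, how an amine or a carboxylic acid in place of fluoro on this aromatic carbon would read stays open. So does whether this order of the three compounds holds at other concentrations.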